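A few compounds are considered here, and "the series" means these few. Any claim that something is new, unique, unknown or untested is made for them only; others in the source may bear on it.

Measured so far:
compound 1, `Nc1nc(-c2ccccc2)nc2sc(-c3ccco3)nc12`: 33 nM
compound 2, `N#Cc1cccc(-c2nc(N)c3nc(-c4ccco4)sc3n2)c1`: 103 nM

In an assay on CHO cells for displacement of a labelled ligand from adenosine receptor A1 (Homo sapiens), read by scintillation counting, with a stated time of 3 h (a higher number here means a weaker inhibitor, a lower number a stronger inhibitor), compound 2 gives the higher of the two numbers, the step of a 3.1-fold higher number from compound 1 to compound 2 (0.49 log units; beyond the scatter) being cyano in place of hydrogen on an aromatic carbon. Compound 3, `Nc1nc(-c2cccc(O)c2)nc2sc(-c3ccco3)nc12`, is not yet measured and differs from compound 2 by hydroxy in place of cyano on an aromatic carbon. Only a 3.1-fold higher number from compound 1 to compound 2 (0.49 log units; beyond the scatter) bears on this change, and it went against the cyano group. Nothing measured here covers hydroxy, so the expectation is a modest return toward compound 1, an expected step of a 2.1-fold lower number from compound 2 to compound 3 (0.31 log units; beyond the scatter). Compound 3 is estimated at 50 nM, with a range from 15 nM to 160 nM.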

Compound 3, inhibition constant: 51 nM
Beside the measured number, compound 3's estimate is 1.0-fold (0.01 log units) below it, within the range that was stated.
By their numbers in this assay, from the lowest: compounds 1 and 3 (each within the scatter of the next); then compound 2.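

In this assay, hydroxy in place of cyano at this position gives a 2.0-fold lower number from compound 2 to compound 3 (0.31 log units; beyond the scatter) and so recovers part of what cyano lost. Hydroxy in place of hydrogen gives a 1.5-fold higher number from compound 1 to compound 3 (0.19 log units; within the scatter) and so cannot be told apart from hydrogen here, whereas cyano can. Nothing at hand explains why these groups differ.

Going by these compounds, whether an amine or a methoxy group at this position would also stay within the scatter of hydrogen remains open. So does whether hydroxy would give the same result elsewhere on this ring.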